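The source may hold more compounds than are shown below. What is called first, only, known or untested is meant among the compounds shown, and "the series" means these compounds.

Among the measured compounds shown here, compound 2 `Cc1cc(C)nc(Sc2ccc(NC(=O)Nc3ccc(Cl)cc3)cc2)n1` is the one compound of this set with a measured number in a functional assay on MGC-803 cells (Homo sapiens) for cytotoxicity, read by MTT assay, with a stated time of 3 days; on this read-out lower numbers stand for stronger inhibition and higher numbers for weaker inhibition: compound 2 gives 26100 nM. Compound 1 `Cc1cc(C)nc(Sc2ccc(NC(=O)Nc3ccc(F)cc3)cc2)n1` differs from it in one place. In this assay compound 1 reaches only the limit of the assay, > 50000 nM. The step of an at least 1.9-fold lower number from compound 1 to compound 2 (0.28 log units; that floor lies within the scatter) is therefore known only as a floor, and that floor rests on (the limit of > 50000 nM in this assay, at which 1 of the 2 values shown sits). Compound 3 `Cc1cc(C)nc(Sc2ccc(NC(=O)Nc3ccc(Cl)cc3Cl)cc2)n1` carries one more substituent than compound 2: chloro in place of hydrogen on an aromatic carbon, the 4-chlorophenyl becoming a 2,4-dichlorophenyl. A single measured step bears on this change, it traded one substituent for another rather than adding one, and its size is uncertain beyond its floor. Compound 3 is thus expected to move by a 1.7-fold lower number from compound 2 to compound 3 (0.24 log units; within the scatter), a step toward a lower number that may not exceed the scatter. For compound 3 the estimate in this assay is 15000 nM, with a range from 5000 nM to 45000 nM.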

Compound 3, half-maximal inhibitory concentration: > 50000 nM
Compound 3: no number, only a limit; the forecaster's own chance of this, stated with the estimate: 20%; middle value at least 3.3-fold (0.52 log units) away from the limit.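

The second chloro, which turns the 4-chlorophenyl into a 2,4-dichlorophenyl and sits ortho to a large group, brings no lower number in this assay: the change gives an at least 1.9-fold higher number from compound 2 to compound 3 (0.28 log units; that floor lies within the scatter). Among the compounds shown here, compound 3 stands only at a limit of the assay, so this step is known as a floor alone, and the one measured number in the set remains that of compound 2, with the readings now bounded as follows: the limit of > 50000 nM in this assay, at which 2 of the 3 values shown sit. Compound 1 and compound 3 both stand at limits, and the step between them cannot be read.

What the compounds shown leave open is whether a bromo, methyl, methoxy or trifluoromethyl group in place of the chloro of compound 2 would give a number clearly apart from its value, which so far has no comparison beyond the scatter. From the compounds shown here alone, it is also open how an amine or a carboxylic acid on the shared core would read in this assay, since every compound here differs only in the halogens of one aromatic ring.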